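The compounds below may be only part of what the source reports. "The series", "measured", "known", "first", "only" and "open" are said of these compounds alone.

Measured so far:
- compound 1, `Cc1ccc(S(=O)(=O)c2cnc3cc(Cl)ccc3c2N2CCC(C)CC2)cc1F`: 85%
- compound 2, `Cc1ccc2ncc(S(=O)(=O)c3cc(Cl)cc(Cl)c3)c(N3CCC(C)CC3)c2c1`: 75%
- compound 3, `COc1ccc2ncc(S(=O)(=O)c3cccc(C#N)c3)c(N3CCC(C)CC3)c2c1`: 90%

All three numbers come from an assay on isolated protein for displacement of a labelled ligand from metabotropic glutamate receptor 5 (Homo sapiens), with a stated time of 60 min, tested at 1 uM; a lower number here means less inhibition, a higher number more inhibition at the concentration tested (going by the name of the read-out). The spread across the set is small: compound 1 sits between the other two, and both of its gaps, to compound 3 and to compound 2, fall within the usual scatter of repeated measurements. On the numbers shown, then, the three compounds cannot be told apart, and no step between any pair of them is established.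

The next compound to run is compound 4, `Cc1ccc(S(=O)(=O)c2cnc3cc(Cl)ccc3c2N2CCC(C)CC2)cc1`. Against compound 1 the difference is hydrogen in place of fluoro on an aromatic carbon.

Among the measured compounds shown here, no measured pair in the set shares this change, so the size of the step has to be guessed. The only material offered is the flatness of the series in this assay and the small size of what leaves. The working expectation is a step from compound 1 to compound 4 of a number 5 percentage points lower from compound 1 to compound 4 (within the scatter), that is, none that stands out from the scatter in either direction. Compound 4 is accordingly estimated at 80%, with the likely range running from 65% to 92%.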

Compound 4, a percentage reported as inhibition, at one concentration (the size of the read-out at that concentration, not a potency): 94%
For compound 4 the middle estimate is 14 percentage points below the measured one, outside the stated range (above it).
By their numbers in this assay, from the lowest: compounds 2, 1, 3 and 4 (each within the scatter of the next, the first and the last beyond it).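

In this assay, among the compounds shown here, the change from 3-fluoro-4-methylphenyl to 4-methylphenyl gives the only step between compounds differing in one place, a number 9 percentage points higher from compound 1 to compound 4 (within the scatter), and this step does not stand out from the scatter. At this aromatic carbon, ortho to the methyl group, hydrogen and fluoro therefore cannot be told apart at the concentration tested, and the fluoro is not needed to keep the inhibition seen with compound 1. No measurement is at hand that would explain this result.

Still open, on these data alone, is whether a trifluoromethyl group, a hydroxyl or an amine in place of the fluoro would move the number beyond the scatter. As far as these compounds go, the finding rests on a single pair, so it also remains open whether the same exchange reads alike with other substituents on the shared core.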